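Taking one methyl off the core of compound 3

The compounds below may be only part of what the source reports. "The series", "measured", "known", "first", "only" and "open" are said of these compounds alone.

Within the data shown here, in a functional assay on MCF7 cells (Homo sapiens) for antiproliferative activity, read by MTT assay (on this read-out lower numbers stand for stronger inhibition and higher numbers for weaker inhibition), compound 2 (`CC/C=C\C/C=C\C/C=C\CCCCCCCc1cc(=O)c2c(O)c(C)c(O)cc2o1`) gives 17500 nM as the only actual number. Compound 1 (`CCCCCCCCCCCCCCCc1cc(=O)c2c(O)c(C)c(OCOC)cc2o1`) reads > 67200 nM as a limit of the assay and not a number. Compound 3 (`CCCCCCCCCCCCCCCc1cc(=O)c2c(O)c(C)c(O)c(C)c2o1`) reads > 67200 nM as a limit as well, and so its standing is known only as a limit.

Compound 4 (`CCCCCCCCCCCCCCCc1cc(=O)c2c(O)c(C)c(O)cc2o1`) comes from compound 3 by one change, hydrogen in place of methyl on an aromatic carbon, and keeps the same chain. Among the measured compounds shown here, no measured pair isolates this change, so the size of the step has to be judged indirectly. The expected guide is compound 2, because compound 2 gives 17500 nM with the same substitution on the core as compound 4 and a different chain. A modest move toward stronger inhibition is therefore expected, and a reading at the limit remains possible. The estimated step is an at least 1.6-fold lower number from compound 3 to compound 4 (0.22 log units; that floor lies within the scatter) in that direction. For compound 4 the estimated value is 40000 nM (expected range 15000 nM to 90000 nM).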

Compound 4, half-maximal inhibitory concentration: 43200 nM
Estimate against measurement, compound 4: 1.1-fold (0.03 log units) below; the measured number falls inside the stated range.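

Hydrogen in place of methyl on this aromatic carbon turns a limit into a measured number in this assay, giving an at least 1.5-fold lower number from compound 3 to compound 4 (0.19 log units; that floor lies within the scatter), and hydrogen in place of methoxymethyl on the oxygen gives an at least 1.5-fold lower number from compound 1 to compound 4 (0.19 log units; that floor lies within the scatter). Neither step shows a true size, and each floor rests on a limit rather than a number: the limit of > 67200 nM in this assay, at which 2 of the 4 values shown sit. Among these compounds, the first measured pair concerns the chain instead, and the group of 8 heavy atoms in place of the group of 10 heavy atoms gives a 2.5-fold higher number from compound 2 to compound 4 (0.39 log units; beyond the scatter), a modest step beyond the scatter.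

As far as these compounds go, it remains open how far compound 3 and compound 1 actually lie from compound 4. Also open, from the compounds shown here alone, is how a longer saturated chain, or an amine in place of the methyl on this aromatic carbon, would read.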